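The source may hold more compounds than are shown below. What is called first, only, known or untested is meant among the compounds shown, and "the series" means these compounds.

Measured so far:
compound 1 `COc1ccc(C[C@H]2COC(=O)[C@@H]2Cc2ccc(OCC(=O)N3CCCCC3)c(OC)c2)cc1OC` — 293000 nM
compound 2 `COC(=O)[C@@H](NC(=O)CCC(=O)Oc1ccc(C[C@H]2C(=O)OC[C@@H]2Cc2ccc(OC)c(OC)c2)cc1OC)c1c[nH]c2ccccc12` — a limit, >= 600000 nM

In an ADME assay on HeLa cells (Homo sapiens) for cytotoxicity, read by MTT assay (on this read-out lower numbers stand for stronger inhibition and higher numbers for weaker inhibition), compound 1 gives 293000 nM. Within the data shown here, this is the only number obtained, so compound 1 stands alone as a measured value, with nothing to rank it against. Compound 2 in this assay gives >= 600000 nM, which is a limit of the assay and not a number. That the series already touches the limit of >= 600000 nM in this assay, at which 1 of the 2 values shown sits, shows how weak the cytotoxicity is in this set.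

Compound 3 `COc1ccc(C[C@H]2COC(=O)[C@@H]2Cc2ccc(OC(=O)CCC(=O)N3CCCC3)c(OC)c2)cc1OC` has not yet been measured in this assay. It differs from compound 1 as follows: a group of 11 heavy atoms (8 carbon, 1 nitrogen, 2 oxygen; one five-membered non-aromatic ring with 1 hetero atom) in place of a group of 9 heavy atoms (7 carbon, 1 nitrogen, 1 oxygen; one six-membered non-aromatic ring with 1 hetero atom), on an oxygen on an aromatic ring. Among the measured compounds shown here, no step between measured compounds has been quantified, so there is no measured reference for the size of this kind of change. The expected step of a 1.4-fold higher number from compound 1 to compound 3 (0.14 log units; within the scatter) is small and, if anything, towards weaker inhibition, since compound 2, which also carries an ester linker of this type on the aromatic oxygen, sits at >= 600000 nM. For compound 3 the expected value is 400000 nM, with an estimated range from 150000 nM to 1000000 nM.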

Compound 3, half-maximal inhibitory concentration: 201000 nM
The estimate for compound 3 lay 2.0-fold (0.30 log units) above the measured number; low and high end bracket the measured number.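

In this assay, the oxygen on an aromatic ring now has its first quantified step: the ((piperidin-1-yl)carbonyl)methyl group of 9 heavy atoms gives way to a group of 11 heavy atoms with a five-membered non-aromatic ring, and the result is a 1.5-fold lower number from compound 1 to compound 3 (0.16 log units; within the scatter). This exchange therefore leaves the number within the scatter, even though the ring size, the heavy-atom count, the double bonds outside aromatic rings and the hydrogen-bond acceptors all change together. Compound 2 gives a limit of the assay and not a number, and the shown values stay in the same weak territory: the limit of >= 600000 nM in this assay, at which 1 of the 3 values shown sits.

Since the ring and the chain that carries it change in a single step, the compounds shown do not separate what each contributes at this oxygen. Also open, on these data alone, is whether an end group of another kind on that oxygen, such as a carboxylic acid or a primary amine, or a longer chain ending in the piperidine ring, would move the number beyond the scatter.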